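The source may hold more compounds than are shown below. What is called first, only, known or untested is meant among the compounds shown, and "the series" means these compounds.

In a functional assay on A-375 cells (Homo sapiens) for cytotoxicity, read by MTT assay, with a stated time of 72 h, tested at 10 uM (a lower number here means less inhibition of growth, a higher number more inhibition of growth at the concentration tested), compound 1 `N/C(=N\NC(=S)N1CCCCC1)c1ccccn1` gives 85.8%. In this assay, going by the values given here, compound 2 `Cc1cccc(/C(N)=N/NC(=S)N2CCCC2)n1` gives 55.9%, the lower of the two numbers measured so far, with a gap to compound 1 that lies beyond the usual scatter. Compound 3 `N/C(=N\NC(=S)N1CCCC1)c1ccccn1` is not yet measured; it differs from compound 2 by hydrogen in place of methyl on an aromatic carbon. Among the compounds with values here, no measured pair shows this single change on its own. A moderate rise is expected, the estimated step being a number 14.1 percentage points higher from compound 2 to compound 3 (beyond the scatter). This rests on compound 1, which also carries no methyl and gives 85.8%. Compound 3 is therefore estimated at 70%, between 50% and 90%.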

Compound 3, percent growth inhibition at one concentration: 83.9%
The estimate for compound 3 lay 13.9 percentage points below the measured number; measured number inside the range.
By their numbers in this assay, from the lowest: compound 2; then compounds 3 and 1 (each within the scatter of the next).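

In this assay hydrogen in place of methyl on an aromatic carbon next to the ring nitrogen gives a number 28 percentage points higher from compound 2 to compound 3 (beyond the scatter) and so shows, as a single change, that methyl at this place goes with less inhibition of growth. Pyrrolidin-1-yl in place of piperidin-1-yl on the thiocarbonyl carbon gives a number 1.9 percentage points lower from compound 1 to compound 3 (within the scatter) and this pair does not separate the two groups. No evidence on the reason for either step is at hand. As far as these compounds go, what an ethyl group, a methoxy group or an amine on this aromatic carbon would give remains open. So does whether methyl there goes with the same step when piperidin-1-yl sits on the thiocarbonyl carbon.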